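Removing the hydroxy on the saturated ring: compound 2 to 3

The source may hold more compounds than are shown below. What is called first, only, known or untested is meant among the compounds shown, and "the series" means these compounds.

compound 1 `CC(=O)c1ccc(NC(=O)C2CCCN2S(=O)(=O)c2ccc([N+](=O)[O-])cc2)cc1`: 25.6%
compound 2 `CC(=O)c1ccc(NC(=O)C2CC(O)CN2S(=O)(=O)c2ccccc2)cc1`: 58.7%

In a functional assay for inhibition, read by spectrophotometry, with a stated time of 20 min, tested at 5 mg/mL (a lower number here means a weaker effect, a higher number a stronger effect of the compound at the concentration tested), compound 2 gives 58.7%, the higher of the two numbers recorded; the nearest, compound 1, sits lower by a gap beyond the scatter. Compound 3 `CC(=O)c1ccc(NC(=O)C2CCCN2S(=O)(=O)c2ccccc2)cc1` differs from compound 2 in one place: hydrogen in place of hydroxy on a saturated ring carbon. Within the data shown here, no measured step of this kind exists among the two compounds, so the direction rests on the change alone; a downward step of moderate size is expected, a number 18.7 percentage points lower from compound 2 to compound 3 (beyond the scatter). Compound 3 is accordingly estimated at 40%, in a range from 20% to 62%.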

Compound 3, a percentage reported as inhibition, at one concentration (the size of the read-out at that concentration, not a potency): 35.7%
For compound 3 the middle estimate is 4.3 percentage points above the measured one, within the range that was stated.
By their numbers in this assay, from the lowest: compound 1; then compound 3; then compound 2.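

In this assay hydrogen in place of hydroxy on a saturated ring carbon gives a number 23 percentage points lower from compound 2 to compound 3 (beyond the scatter) and so shows that this ring position matters to the read-out. Compound 3 also makes the aromatic position readable as a single change: hydrogen in place of nitro gives a number 10.1 percentage points higher from compound 1 to compound 3 (beyond the scatter) and is the smaller of the two steps. No evidence bears on the cause of either step.

On these data alone, whether a methoxy or an amine on the saturated ring carbon would keep the number of compound 2 remains open. So does the effect of a carboxylic acid in place of nitro on the aromatic carbon.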